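Aryl hydrazone variation on a shared urea core

This account rests on a few compounds, and the source may have more. Where it says the series, first, only, none or still open, it means among the compounds named here.

Measured compounds:
Compound 1 `CN(C)CCn1cnnc1-c1cc(Oc2ccc(NC(=O)N/N=C/c3c(Cl)cccc3Cl)cc2F)ccn1`; in a functional assay on MKN-45 cells (Homo sapiens) for cytotoxicity, read by MTT assay, with a stated time of 72 h (a higher number here means a weaker inhibitor, a lower number a stronger inhibitor), compound 1 gives 160 nM.
Compound 2 `CN(C)CCn1cnnc1-c1cc(Oc2ccc(NC(=O)N/N=C/c3ccc(O)c(Br)c3)cc2F)ccn1`; in this assay compound 2 gives 1860 nM.
Compound 3 `COc1cc(/C=N/NC(=O)Nc2ccc(Oc3ccnc(-c4nncn4CCN(C)C)c3)c(F)c2)cc(OC)c1OC`; in this assay compound 3 gives 2900 nM.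

Compound 3 carries the highest number of the three. Its nearest neighbour is compound 2, and the two lie within the scatter of each other (a 1.6-fold higher number from compound 2 to compound 3 (0.19 log units; within the scatter)), whereas compound 1 stands well apart (an 18-fold higher number from compound 1 to compound 3 (1.26 log units; beyond the scatter)).

Compound 4 `CN(C)CCn1cnnc1-c1cc(Oc2ccc(NC(=O)N/N=C/c3cccc(Br)c3)cc2F)ccn1` differs from compound 3 in one place: 3-bromophenyl in place of 3,4,5-trimethoxyphenyl on a carbon with a double bond to nitrogen. For the measured compounds named here, the steps that bear on this are the two departures from the 2,6-dichlorophenyl of compound 1: a 12-fold higher number from compound 1 to compound 2 (1.07 log units; beyond the scatter) and an 18-fold higher number from compound 1 to compound 3 (1.26 log units; beyond the scatter), both large, and both arriving at rings that carry oxygen. Going by the values given here, no measured step shows a ring with a bromine alone. Compound 4 shares its bromine with compound 2 but drops the hydroxyl, and is closer in its lack of acceptors to compound 1. The expectation for compound 4 is therefore a step down from compound 3 beyond the scatter, short of the number of compound 1: a 4.1-fold lower number from compound 3 to compound 4 (0.62 log units; beyond the scatter). In this assay compound 4 is estimated at 700 nM, with a range from 250 nM to 2500 nM.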

Compound 4, half-maximal inhibitory concentration: 450 nM
Beside the measured number, compound 4's estimate is 1.6-fold (0.19 log units) above it, and the stated range covers the measured number.
By their numbers in this assay, from the lowest: compound 1; then compound 4; then compounds 2 and 3 (each within the scatter of the next).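

In this assay, for the compounds shown here, the hydroxy group of compound 2 can be read on its own for the first time: hydrogen in its place on an aromatic carbon gives a clear gain (a 4.1-fold lower number from compound 2 to compound 4 (0.62 log units; beyond the scatter)), so the bromine-bearing ring does not need that hydroxy to reach the lower numbers. The ring with no oxygen also separates from the 3,4,5-trimethoxyphenyl ring on the carbon with a double bond to nitrogen (a 6.4-fold lower number from compound 3 to compound 4 (0.81 log units; beyond the scatter)), yet it still does not match the 2,6-dichlorophenyl ring (a 2.8-fold higher number from compound 1 to compound 4 (0.45 log units; beyond the scatter)), so the absence of oxygen on this ring does not close the whole gap to compound 1. Nothing in the data shown gives a reason for any of these steps.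

Open, from the compounds shown here alone, is where an unsubstituted phenyl would fall relative to compound 4, which would show what the bromine itself contributes. Also open, going by these compounds, is how a ring carrying an amine or a carboxylic acid, or a single chlorine in place of the two chlorines of compound 1, would compare.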